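Swapping the Aryl Group on the Sulfonyl Nitrogen Substituent

The compounds below may be only part of what the source reports. "The series", "measured", "known", "first", "only" and "open" are said of these compounds alone.

compound 1 `COc1ccc(-c2cc(=O)c3c(OC)cc(OC)cc3[nH]2)cc1` — > 62000 nM
compound 2 `COc1ccc(-c2cc(=O)c3c(OC)cc(OC)cc3n2S(=O)(=O)c2ccc(C#N)cc2)cc1` — 7900 nM
compound 3 `COc1ccc(-c2cc(=O)c3c(OC)cc(OC)cc3n2S(=O)(=O)c2cc(Cl)cc(Cl)c2O)cc1` — not yet measured

Compound 1 carries hydrogen on its aromatic nitrogen. In a functional assay on SUP-B15 cells (Homo sapiens) for antiproliferative activity, with a stated time of 72 h (a lower number here means that less compound is needed, a higher number that more compound is needed for the effect), compound 1 reaches only the assay limit and is recorded as > 62000 nM. Compound 2 carries (4-cyanophenyl)sulfonyl on that nitrogen, and in this assay compound 2 gives 7900 nM. That is the only number shown in this assay; the other entry is a limit. For the measured compounds named here, the single measured step, an at least 7.8-fold lower number from compound 1 to compound 2 (0.89 log units; beyond the scatter), is the whole of the evidence, with compound 1 sitting at the limit of > 62000 nM in this assay, at which 1 of the 2 values shown sits.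

Compound 3 differs from compound 2 by 3,5-dichloro-2-hydroxyphenyl in place of 4-cyanophenyl on a sulfonyl sulfur. Going by the values given here, no measured step changes the aryl group on the sulfonyl sulfur; the one step recorded concerns attaching the sulfonyl group itself, and compound 3 keeps it. Compound 3 is therefore expected to show a step of only a 1.3-fold lower number from compound 2 to compound 3 (0.12 log units; within the scatter) in this assay, not beyond the scatter. The estimate for compound 3 in this assay is 6000 nM, within 1500 nM to 25000 nM.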

Compound 3, half-maximal effective concentration: > 37900 nM
Compound 3 gave a limit, no number (the forecaster's own chance of this, stated with the estimate: 10%); at least 6.3-fold (0.80 log units) between middle value and limit.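

The aryl group on the sulfonyl sulfur proves not to be interchangeable: in this assay the change from 4-cyanophenyl to 3,5-dichloro-2-hydroxyphenyl gives an at least 4.7-fold higher number from compound 2 to compound 3 (0.68 log units; beyond the scatter), so keeping the sulfonyl group on the aromatic nitrogen does not by itself preserve the number seen for compound 2. Compound 3 ends at a limit rather than a number, so the step has a lower bound but no known size: the limit of > 37900 nM in this assay, at which 1 of the 3 values shown sits. Compound 1 also ends at a limit, which leaves compound 2 as the only one of the three with a number and gives no way of ordering compound 1 and compound 3: the limit of > 62000 nM in this assay, at which 1 of the 3 values shown sits.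

With only two aryl groups shown on the sulfonyl sulfur, the compounds cannot separate the part played by the hydroxyl from that of the two chlorines in 3,5-dichloro-2-hydroxyphenyl, nor the part played by losing the nitrile. They also leave open what an amine or a carboxylic acid on that aryl ring, or a plain methyl in place of the aryl group on the sulfonyl sulfur, would give in this assay.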